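The source may hold more compounds than are shown below. What is called first, only, known or untested is meant among the compounds shown, and "the series" means these compounds.

In a functional assay on HCT-116 cells (Homo sapiens) for cytotoxicity, read by MTT assay, with a stated time of 48 h (on this read-out lower numbers stand for stronger inhibition and higher numbers for weaker inhibition), compound 1 `COc1ccc(-c2nc(C(=O)/C=C\Nc3ccc4[nH]ccc4c3)c3ccccn23)cc1` gives 17400 nM. Compound 2 `COc1ccc(N/C=C\C(=O)c2nc(-c3ccc(C(F)(F)F)cc3)n3ccccc23)cc1OC` reaches only a limit of the assay, > 30000 nM. Compound 3 `O=C(/C=C\Nc1ccc2cc[nH]c2c1)c1nc(-c2ccc(C(F)(F)F)cc2)n2ccccc12` likewise reaches only a limit, > 30000 nM, so it stands at the limit of > 30000 nM in this assay, at which 2 of the 3 values shown sit, and no number places it. Among the compounds with values here, the single measured step, a step that the two limits leave unreadable from compound 2 to compound 3, runs between two limits and so reads no size. Compound 4 `O=C(/C=C\Nc1ccc2[nH]ccc2c1)c1nc(-c2ccc(C(F)(F)F)cc2)n2ccccc12` differs from compound 3 by 1H-indol-5-yl in place of 1H-indol-6-yl on an amine nitrogen. Within the data shown here, no measured step touches this change, and the step between the two limits gives no direction. Compound 1, which also carries the 1H-indol-5-yl group on its amine nitrogen with a different aryl group elsewhere, gives 17400 nM. One therefore expects no step beyond the scatter, a number no higher from compound 3 to compound 4 (the limit leaves the size open), and estimates compound 4 at 30000 nM, within 15000 nM to 60000 nM.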

Compound 4, half-maximal inhibitory concentration: 27100 nM
The estimate for compound 4 lay 1.1-fold (0.04 log units) above the measured number; the range from low to high includes it.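

In this assay, compound 4 is the only trifluoromethyl compound shown that gives a number rather than a limit: the limit of > 30000 nM in this assay, at which 2 of the 4 values shown sit. Its steps are an at least 1.1-fold lower number from compound 3 to compound 4 (0.04 log units; that floor lies within the scatter) and an at least 1.1-fold lower number from compound 2 to compound 4 (0.04 log units; that floor lies within the scatter), so the 1H-indol-5-yl group gives a number, but neither floor shows a change beyond the scatter. With 1H-indol-5-yl on the amine nitrogen, the aryl change gives a 1.6-fold higher number from compound 1 to compound 4 (0.19 log units; within the scatter). Going by these compounds, how large the steps behind the two limits really are stays open. So does how a chlorine or a carboxylic acid in place of trifluoromethyl would read.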